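A Methoxy Added to the Phenyl of Compound 1

The compounds below may be only part of what the source reports. "The series", "measured", "known", "first", "only" and "open" are said of these compounds alone.

Compound 1, `COc1cc(/C=C/C(=O)c2cccc(-n3cc(-c4ccccc4)[nH]c3=O)c2)ccc1O`, gives 2600 nM in a functional assay on NCI-H226 cells (Homo sapiens) for inhibition; a higher number here means a weaker inhibitor of growth, a lower number a stronger inhibitor of growth.
Compound 2, `O=C(/C=C/c1cccc(O)c1)c1cccc(-n2cc(-c3ccccc3)[nH]c2=O)c1`, gives 24800 nM in this assay.
Compound 3, `COc1cc(/C=C/C(=O)c2cccc(-n3cc(-c4ccccc4)[nH]c3=O)c2)cc(OC)c1OC`, gives 14600 nM in this assay.

Among these three, compound 1 has the lowest number, and both gaps to it lie beyond the scatter: compound 3 sits higher, and compound 2 higher still, the latter by the step of a 9.5-fold higher number from compound 1 to compound 2 (0.98 log units; beyond the scatter), which exchanged the aryl group on the double-bonded chain carbon.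

Compound 4, `COc1ccc(-c2cn(-c3cccc(C(=O)/C=C/c4ccc(O)c(OC)c4)c3)c(=O)[nH]2)cc1`, differs from compound 1 at a different place: methoxy in place of hydrogen on an aromatic carbon. This is the phenyl that hangs from the shared core, not the aryl on the chain. Among the compounds with values here, none of the measured steps touches that phenyl; the only step known, from compound 1 to compound 2, and the gap between compound 1 and compound 3 both concern the chain aryl. So nothing in the numbers speaks directly to the change in compound 4, and a step is expected to be small, quite possibly none beyond the scatter, in either direction; the estimate leans slightly toward a higher number, a 1.2-fold higher number from compound 1 to compound 4 (0.09 log units; within the scatter). Compound 4 is therefore expected to give 3200 nM, within a range of 1200 nM to 9000 nM.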

Compound 4, concentration for 50% growth inhibition: 4100 nM
For compound 4 the middle estimate is 1.3-fold (0.11 log units) below the measured one; low and high end bracket the measured number.
By their numbers in this assay, from the lowest: compounds 1 and 4 (each within the scatter of the next); then compounds 3 and 2 (each within the scatter of the next).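

Within the data shown here, compound 4 gives the first reading on the phenyl that hangs from the shared core: in this assay, the change from phenyl to 4-methoxyphenyl, on an aromatic carbon para to a large group, comes to a 1.6-fold higher number from compound 1 to compound 4 (0.20 log units; within the scatter). This single step shows that methoxy in place of hydrogen at this position leaves the number within the scatter, whereas the exchange of the aryl on the chain gave a 9.5-fold higher number from compound 1 to compound 2 (0.98 log units; beyond the scatter), which lies beyond it. No measurement among the data accounts for this result, so the small size of the step stays a plain observation.

What the compounds shown leave open is whether this position accepts other groups as readily, since one methoxy cannot show how an amine or a carboxylic acid on the same aromatic carbon would read in this assay. As far as these compounds go, it also remains open whether the 4-methoxyphenyl would give a step of similar size alongside the chain aryl of compound 2 or compound 3.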